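This account rests on a few compounds, and the source may have more. Where it says the series, first, only, none or still open, it means among the compounds named here.

Measured so far in a physicochemical assay for lipophilicity; on this read-out lower numbers stand for lower lipophilicity and higher numbers for higher lipophilicity:
- compound 1 `CCCCCCCCCCCCCCOCC(COc1ccc(Cc2noc(=O)[nH]2)cc1)Oc1ccc(Cc2noc(=O)[nH]2)cc1`: 7.64
- compound 2 `CCCCCCCCCCCCCCOC(COCc1cccc(OC)c1)COc1ccc(-c2noc(=O)[nH]2)cc1`: 8.56
- compound 3 `CCCCCCCCCCCCCCOC(COc1ccc(Cc2noc(=O)[nH]2)cc1)COc1ccc(Cc2noc(=O)[nH]2)cc1`: 7.64

Compound 2 gives the highest of the three numbers in this assay. The nearest value among the rest is that of compound 1, which lies lower by a gap beyond the scatter; compound 3 stands at the same distance below, so compound 2 is set apart from both on this read-out. Compound 1 and compound 3 sit at the same value, so nothing separates them here.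

The next compound in the series is compound 4 `CCCCCCCCCCCCCCOC(COCCCCC)COc1ccc(-c2noc(=O)[nH]2)cc1`, which has not been measured yet. Relative to compound 2 the change is butyl in place of 3-methoxyphenyl on a saturated chain carbon bound to an oxygen on a saturated carbon. Among the measured compounds shown here, no measured pair in the set differs in just one place, so there is no measured step to lean on for this change; the expectation rests on the structures alone.

A group with an aromatic ring and one hydrogen-bond acceptor leaves and a shorter saturated chain without acceptors enters. On balance the step from compound 2 to compound 4 in this assay is expected to be small and, if anything, slightly downward, most likely within the scatter: a number 0.16 log units lower from compound 2 to compound 4 (within the scatter). Compound 4 is therefore estimated at 8.4 in this assay, with a range from 7.9 to 8.9.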

Compound 4, partition coefficient: 8.72
Compound 4: the middle estimate sits 0.32 log units below what was measured; measured number inside the range.
By their numbers in this assay, from the lowest: compounds 1 and 3 (each within the scatter of the next); then compounds 2 and 4 (each within the scatter of the next).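

In this assay, the position on a saturated chain carbon bound to an oxygen on a saturated carbon now has its first readable step: replacing 3-methoxyphenyl with butyl gives a number 0.16 log units higher from compound 2 to compound 4 (within the scatter). Among the compounds shown here, the six-membered aromatic ring and the hydrogen-bond acceptor of 3-methoxyphenyl can therefore be exchanged for the ringless, acceptor-free butyl without a change that stands clear of the scatter on this read-out, a point the earlier compounds could not address because no pair among them differed in one place. No measured information bears on why these two groups read alike.

For the compounds shown here, this single pair is the only evidence for the position, so it remains open how a group carrying an amine or a carboxylic acid, or a longer chain such as octyl, would read there. Going by these compounds alone, it is also open whether the exchange of 3-methoxyphenyl for butyl would read the same on another core, since compound 1 and compound 3 differ from compound 2 and compound 4 in more than one place and provide no step.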